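A few compounds are considered here, and "the series" means these few. Any claim that something is new, unique, unknown or untested is made for them only; others in the source may bear on it.

In an ADME assay on a cell-free system (plasma, Homo sapiens) for metabolic stability, tested at 1 uM (on this read-out higher numbers stand for a longer-lived compound and lower numbers for a shorter-lived compound), compound 1 `C=CC(=O)N1CCN(S(=O)(=O)c2ccc(NC(=O)OCc3ccccc3)cc2)CC1` gives > 6 h, which is a limit and not a number. In this assay compound 2 `C=CC(=O)NC1CN(S(=O)(=O)c2ccc(NC(=O)OCc3ccccc3)cc2)C1` gives > 6 h, again a limit. In this assay, on these data alone, compound 3 `C=CC(=O)NC1CCN(S(=O)(=O)c2ccc(C(=O)NCc3ccccc3)cc2)CC1` gives > 6 h, also a limit, so its true half-life remains unknown. The series therefore sits at one ceiling: the limit of > 6 h in this assay, at which 3 of the 3 values shown sit.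

Compound 4 `C=CC(=O)NC1CCN(S(=O)(=O)c2ccc(C(=O)N[C@@H]3C[C@H]3c3ccccc3)cc2)CC1` carries 2-phenylcyclopropyl in place of benzyl on an amide-type nitrogen. Within the data shown here, the only measured step, a step that the two limits leave unreadable from compound 1 to compound 2, has limits at both ends and lies at a different place, on a sulfonyl sulfur. Among the measured compounds shown here, it gives no size to carry over, and no measured step covers this change. With nothing to indicate a shift in either direction, the expected step that the limit leaves unreadable from compound 3 to compound 4 stays within the scatter. That expectation rests on the limit of compound 3, > 6 h. Another limit is the likeliest report in this assay. For compound 4 the estimate is 8 h, with an expected range of 4 h to 16 h.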

Compound 4, half-life: > 6 h
Compound 4: no number, only a limit; the forecaster's own chance of this, stated with the estimate: 85%; the middle value lies beyond the limit too.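

Compound 3 and compound 4 both report only a limit in this assay, so no step can be read for 2-phenylcyclopropyl in place of benzyl: the limit of > 6 h in this assay, at which 4 of the 4 values shown sit.

The compounds shown leave open the true half-life of each compound in this assay and whether any change among them shifts it.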